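The source may report more compounds than this note shows. Statements on the series, on what has been measured and on what is new or still open speak of the compounds shown alone.

In a functional assay on KARPAS-422 cells (Homo sapiens) for antiproliferative activity, read by resazurin assay, with a stated time of 72 h (a lower number here means a stronger inhibitor, a higher number a weaker inhibitor), compound 2 (`Cc1cc(C)c(CN2CCc3c(Cl)cc([C@@H](CO)[C@@H]4CCOC4)c(Cl)c3C2=O)c(=O)[nH]1`) gives 3950 nM, the higher of the two single numbers, while its mirror image, compound 1 (`Cc1cc(C)c(CN2CCc3c(Cl)cc([C@H](CO)[C@H]4CCOC4)c(Cl)c3C2=O)c(=O)[nH]1`), gives 15 nM. That gap, a 260-fold higher number from compound 1 to compound 2 (2.42 log units; beyond the scatter), comes with the fact that compounds 1 and 2 differ only in the configuration as drawn. Compound 3 (`CCOC(c1cc(Cl)c2c(c1Cl)C(=O)N(Cc1c(C)cc(C)[nH]c1=O)CC2)C1CS(=O)(=O)C1`) has two entries, 5560 nM; 34 nM (2 entries), which are also far apart. Compound 4 (`Cc1cc(C)c(CN2CCc3c(Cl)cc([C@@H](CO)[C@@H]4CCCO4)c(Cl)c3C2=O)c(=O)[nH]1`) differs from compound 2 as follows: oxolan-2-yl in place of oxolan-3-yl on a saturated chain carbon bound to an aromatic carbon and a saturated chain carbon. That is, oxolan-2-yl stands in place of oxolan-3-yl on a saturated chain carbon. Among the measured compounds shown here, no measured step covers this swap, but compound 4 is drawn with the chain-carbon handedness of compound 2, which gives 3950 nM, so a weak result is expected. The expected change is a 1.6-fold lower number from compound 2 to compound 4 (0.20 log units; within the scatter), with no clear shift beyond the scatter. For compound 4 the estimate is 2500 nM, with an expected range from 300 nM to 9000 nM.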

Compound 4, half-maximal inhibitory concentration: 1220 nM
Beside the measured number, compound 4's estimate is 2.0-fold (0.31 log units) above it; the range from low to high includes it.
By their numbers in this assay, from the lowest: compound 1; then compound 4; then compound 2.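

Changing oxolan-3-yl to oxolan-2-yl on this saturated chain carbon has a measurable but modest effect in this assay: a 3.2-fold lower number from compound 2 to compound 4 (0.51 log units; beyond the scatter). A far larger distance remains on the other side, an 81-fold higher number from compound 1 to compound 4 (1.91 log units; beyond the scatter). The swap therefore closes only part of the gap within the mirror-image pair, a 260-fold higher number from compound 1 to compound 2 (2.42 log units; beyond the scatter), whose members stand apart in one respect alone: the fact that compounds 1 and 2 differ only in the configuration as drawn.

From the compounds shown here alone, it remains open how oxolan-2-yl would behave in the opposite configuration, and which of the two stereocentres carries the gap. Also open, going by these compounds, is how an amine such as pyrrolidin-3-yl would perform in this place.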